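Replacing 4-methoxyphenyl with pyridin-4-yl on the shared core

The source may report more compounds than this note shows. Statements on the series, on what has been measured and on what is new or still open speak of the compounds shown alone.

Values measured in an ADME assay on A549 cells (Homo sapiens) for cytotoxicity, read by resazurin assay, with a stated time of 48 h; on this read-out lower numbers stand for higher toxicity in this test and higher numbers for lower toxicity in this test:
- compound 1 `O=C(Nc1ccc(NCC2CCCC2)cc1Cl)c1cc(Cl)ccc1O` gives 21500 nM
- compound 2 `O=C(Nc1ccc(NCc2ccccc2)cc1Cl)c1cc(Cl)ccc1O` gives 19700 nM
- compound 3 `COc1ccc(CNc2ccc(NC(=O)c3cc(Cl)ccc3O)c(Cl)c2)cc1` gives 80700 nM

Compound 3 has the highest number of the three, and its gaps to the other two lie beyond the scatter. Compound 4 `O=C(Nc1ccc(NCc2ccncc2)cc1Cl)c1cc(Cl)ccc1O` differs from compound 3 by one change on a saturated chain carbon bound to a nitrogen on an aromatic ring, pyridin-4-yl in place of 4-methoxyphenyl (pyridin-4-yl in place of 4-methoxyphenyl on a saturated chain carbon bound to a nitrogen on an aromatic ring). The closest measured step is a 4.1-fold higher number from compound 2 to compound 3 (0.61 log units; beyond the scatter), where methoxy takes the place of hydrogen on an aromatic carbon. The step of a 3.8-fold higher number from compound 1 to compound 3 (0.57 log units; beyond the scatter) is of similar size, whereas a 1.1-fold lower number from compound 1 to compound 2 (0.04 log units; within the scatter) shows cyclopentyl and phenyl level in this assay. Compound 4 has no methoxy group, so a return toward compound 2 at 19700 nM seems likely. Among the measured compounds shown here, no measured compound carries pyridin-4-yl, which leaves the range wide. A modest fall is expected, an estimated 2.7-fold lower number from compound 3 to compound 4 (0.43 log units; beyond the scatter). For compound 4 the estimate is 30000 nM, with an expected range from 11000 nM to 80000 nM.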

Compound 4, half-maximal cytotoxic concentration: 65300 nM
For compound 4 the middle estimate is 2.2-fold (0.34 log units) below the measured one; the range from low to high includes it.
By their numbers in this assay, from the lowest: compounds 2 and 1 (each within the scatter of the next); then compounds 4 and 3 (each within the scatter of the next).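

Swapping 4-methoxyphenyl for pyridin-4-yl at this position leaves the number level in this assay (a 1.2-fold lower number from compound 3 to compound 4 (0.09 log units; within the scatter)), so the higher numbers seen here do not depend on a methoxy group. Pyridin-4-yl also stands clearly apart from phenyl (a 3.3-fold higher number from compound 2 to compound 4 (0.52 log units; beyond the scatter)) and from cyclopentyl (a 3.0-fold higher number from compound 1 to compound 4 (0.48 log units; beyond the scatter)), which divides the four compounds into two level pairs: compounds 1 and 2 at the lower numbers, compounds 3 and 4 at the higher. No measured evidence explains why these two different groups sit together. As far as these compounds go, whether pyridin-3-yl or pyridin-2-yl, with the ring nitrogen placed elsewhere, would join compounds 3 and 4 remains open. So does the fate of a 4-hydroxyphenyl or a 4-carboxyphenyl group on the same saturated chain carbon.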